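Swapping the aryl group on a shared kinase-inhibitor core

The source may hold more compounds than are shown below. What is called first, only, known or untested is meant among the compounds shown, and "the series" means these compounds.

Compound 1: `COc1cc2c(Oc3ccc(NC(=O)c4cc(-c5ccc(C)cc5)nc5ccccc45)cc3F)ccnc2cc1OCCCN1CCCC1`, 300 nM
Compound 2: `COc1cccc(-c2cc(C(=O)Nc3ccc(Oc4ccnc5cc(OCCCN6CCCCC6)c(OC)cc45)c(F)c3)c3cc(F)ccc3n2)c1`, 690 nM

Both compounds were tested in a functional assay on MKN-45 cells (Homo sapiens) for cytotoxicity, read by MTT assay, with a stated time of 72 h; on this read-out lower numbers stand for stronger inhibition and higher numbers for weaker inhibition. Compound 1 gives 300 nM in this assay, and compound 2 gives 690 nM, the higher of the two numbers; the gap between them lies beyond the usual scatter of this measurement. Compound 3, `COc1cc2c(Oc3ccc(NC(=O)c4cc(-c5ccc(Cl)cc5Cl)nc5ccc(F)cc45)cc3F)ccnc2cc1OCCCN1CCCCC1`, has not yet been measured. It differs from compound 2 in one place: 2,4-dichlorophenyl in place of 3-methoxyphenyl on an aromatic carbon next to the ring nitrogen of the shared core. Among the compounds with values here, with only two measured compounds and no pair differing in a single place, there is no guide to how large such a change is here. A modest shift toward a lower number is expected for compound 3, which corresponds to the step of a 1.4-fold lower number from compound 2 to compound 3 (0.14 log units; within the scatter). Compound 3 is thus estimated to give 500 nM, within a range from 150 nM to 1700 nM.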

Compound 3, half-maximal inhibitory concentration: 250 nM
Compound 3: middle estimate off by 2.0-fold (0.30 log units), on the high side, within the range that was stated.
By their numbers in this assay, from the lowest: compounds 3 and 1 (each within the scatter of the next); then compound 2.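

Within the data shown here, this is the first single-place step in the set, and it shows that the aryl group on the aromatic carbon next to the ring nitrogen of the shared core affects the result. In this assay, replacing 3-methoxyphenyl with 2,4-dichlorophenyl gives a 2.8-fold lower number from compound 2 to compound 3 (0.44 log units; beyond the scatter), so a ring with two chlorines and no hydrogen-bond acceptor is accepted here and gives the lower number. Nothing measured here explains the size of this step.

A single exchange cannot separate the loss of the methoxy group from the gain of the chlorines; a plain phenyl ring or a phenyl ring with one chlorine would help to do so. As far as these compounds go, how an amine on this aryl ring, or a pyridine ring in its place, would behave also remains open.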